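Nitro Substitution on a Sulfonyl Imidazole Without Measured Precedent

A few compounds are considered here, and "the series" means these few. Any claim that something is new, unique, unknown or untested is made for them only; others in the source may bear on it.

The measured compounds so far:
compound 1 `COc1cc(C(=O)n2ccnc2-c2ccccc2)cc(OC)c1OC` gives > 10000 nM in a functional assay on LNCaP cells (Homo sapiens) for cytotoxicity, read by sulforhodamine B assay, with a stated time of 48 h (a higher number here means a weaker inhibitor, a lower number a stronger inhibitor), a limit of the assay.
Compound 2 `COc1ccc(C(=O)n2ccnc2-c2ccccc2)cc1` gives > 10000 nM in this assay, also a limit.
Compound 3 `O=S(=O)(c1ccccc1)n1ccnc1-c1ccccc1` gives > 10000 nM in this assay, again a limit and not a number.

Compound 3 therefore stands where every compound here stands: at the limit of > 10000 nM in this assay, at which 3 of the 3 values shown sit. For the measured compounds named here, no step between two measured compounds is available, since all three values are limits, and nothing yet shows which change moves the read-out away from that limit.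

Compound 4 `O=[N+]([O-])c1ccc(-c2nccn2S(=O)(=O)c2ccccc2)cc1` differs from compound 3 by nitro in place of hydrogen on an aromatic carbon. Going by the values given here, with no measured step to draw on, the step from compound 3 to compound 4 is expected to be a number no higher from compound 3 to compound 4 (the limit leaves the size open), which is to say no shift beyond the scatter, and the most likely outcome is another limit. Compound 4 is accordingly estimated at 10000 nM, with a range from 2000 nM to 30000 nM.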

Compound 4, half-maximal inhibitory concentration: > 10000 nM
Compound 4: no number, only a limit; the forecaster's own chance of this, stated with the estimate: 60%; the middle value lies on the limit itself.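

In this assay, for the compounds shown here, compound 3 and compound 4 both give only a limit and not a number, so no step between them can be read. The compounds shown leave open which change, if any, moves the read-out away from where they all stand: the limit of > 10000 nM in this assay, at which 4 of the 4 values shown sit.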